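Swapping a Benzyl for a Sulfonyl Group

The source may hold more compounds than are shown below. What is called first, only, known or untested is meant among the compounds shown, and "the series" means these compounds.

In an ADME assay on MT4 cells (Homo sapiens) for cytotoxicity (on this read-out lower numbers stand for higher toxicity in this test and higher numbers for lower toxicity in this test), compound 1 (`Cc1cc(C)cc(S(=O)(=O)n2c(SCC(=O)Nc3ccccc3Cl)nc3ccc(Cl)cc32)c1`) gives 99300 nM. Compound 2 (`Cc1cc(C)cc(Cn2c(SCC(=O)Nc3ccc(S(C)(=O)=O)cc3Cl)nc3ccc(Cl)cc32)c1`) gives 88800 nM, so the two values lie within the scatter of each other. Compound 3 (`Cc1cc(C)cc(S(=O)(=O)n2c(SCC(=O)Nc3ccc(S(C)(=O)=O)cc3Cl)nc3ccc(Cl)cc32)c1`) has (3,5-dimethylphenyl)sulfonyl in place of the 3,5-dimethylbenzyl of compound 2 on an aromatic nitrogen: (3,5-dimethylphenyl)sulfonyl in place of 3,5-dimethylbenzyl on an aromatic nitrogen. Going by the values given here, no measured pair shows this change alone. Compound 1 already carries that sulfonyl group, though it differs elsewhere too, and its 99300 nM gives no sign of a shift, so no step beyond the scatter is expected. The expected change is a 1.0-fold lower number from compound 2 to compound 3 (0.02 log units; within the scatter). For compound 3 the estimated value is 85000 nM, with a range from 35000 nM to 200000 nM.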

Compound 3, half-maximal cytotoxic concentration: 3590 nM
Estimate against measurement, compound 3: 24-fold (1.37 log units) above; the measured number lies below the stated range.
By their numbers in this assay, from the lowest: compound 3; then compounds 2 and 1 (each within the scatter of the next).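

In this assay, the swap on this aromatic nitrogen proves far from neutral, giving a 25-fold lower number from compound 2 to compound 3 (1.39 log units; beyond the scatter). Compound 1 carries the same (3,5-dimethylphenyl)sulfonyl without the methylsulfonyl, and adding that group gives a 28-fold lower number from compound 1 to compound 3 (1.44 log units; beyond the scatter). The sulfonyl group's effect therefore depends on what else the molecule carries, and only compound 3 holds both groups.

Nothing available explains this dependence. Going by these compounds, whether a benzoyl group on that nitrogen, or a carboxylic acid in place of the methylsulfonyl, would give a similar drop remains open.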